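The source may hold more compounds than are shown below. What is called first, only, known or untested is meant among the compounds shown, and "the series" means these compounds.

The series is built around a diaryl ether urea with an acylhydrazone arm, and compound 2 `CN(C)CCn1cnnc1-c1cc(Oc2ccc(NC(=O)N/N=C/c3ccc(O)c(Br)c3)cc2F)ccn1` is the point of departure. In a functional assay on NCI-H460 cells (Homo sapiens) for cytotoxicity, read by MTT assay, with a stated time of 72 h (on this read-out lower numbers stand for stronger inhibition and higher numbers for weaker inhibition), compound 2 gives 430 nM, the lowest number among the three measured compounds. Compound 1 `CN(C)CCn1cnnc1-c1cc(Oc2ccc(NC(=O)N/N=C/c3cc(C(C)(C)C)cc(C(C)(C)C)c3O)cc2F)ccn1`, which carries two tert-butyl groups on its phenol ring, gives 590 nM in this assay, and the two values sit within the scatter of each other, so no order between compound 1 and compound 2 can be read from them. Compound 3 `Cn1ncnc1-c1cc(Oc2ccc(NC(=O)N/N=C/c3ccccc3)cc2F)ccn1`, with an unsubstituted phenyl ring on the hydrazone and a methyl rather than a dimethylaminoethyl group on its triazole, gives 52200 nM, a number far beyond the scatter away from that of compound 2.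

Compound 4 `CN(C)CCn1cnnc1-c1cc(Oc2ccc(NC(=O)N/N=C/c3ccc(O)c(O)c3)cc2F)ccn1` differs from compound 2 in a single place: hydroxy in place of bromo on an aromatic carbon, so the ring becomes a catechol. Going by the values given here, no step between measured compounds isolates this exchange, so the direction must be guessed from what the three measured compounds show. Compound 4 is expected to lose a little ground, with a step of a 3.5-fold higher number from compound 2 to compound 4 (0.54 log units; beyond the scatter), since a substituted phenol is retained but the bromo is gone. Compound 4 is therefore estimated at 1500 nM, with a plausible range from 400 nM to 6000 nM.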

Compound 4, half-maximal inhibitory concentration: 1930 nM
The estimate for compound 4 lay 1.3-fold (0.11 log units) below the measured number, and the stated range covers the measured number.
By their numbers in this assay, from the lowest: compounds 2 and 1 (each within the scatter of the next); then compound 4; then compound 3.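

Going by these compounds alone, the pair of compound 2 and compound 4 is the first comparison here that differs in one place only, and in this assay it gives a direct reading of this position: hydroxy in place of bromo on an aromatic carbon, ortho to a hydroxy group, brings a 4.5-fold higher number from compound 2 to compound 4 (0.65 log units; beyond the scatter) and so costs ground beyond the scatter. With the rest of the molecule unchanged, the 3-bromo-4-hydroxyphenyl ring therefore gives the lower number and the 3,4-dihydroxyphenyl ring the higher, which shows that the group on this carbon affects the read-out, although this single exchange is only a modest step. The data offer no measurement that explains why the two groups differ on this read-out.

Going by these compounds, whether another group on this carbon, such as chloro, methoxy or an amine, would fall with the bromo, with the hydroxy or elsewhere remains open. So does whether the same exchange would give a step of similar size with a different group in place of the dimethylaminoethyl chain on the triazole.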